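The source may hold more compounds than are shown below. What is called first, only, known or untested is meant among the compounds shown, and "the series" means these compounds.

Compound 1, `COC(=O)/C=C/c1cccc(N(Cc2ccc(/C=C/c3c(C)cc(C)cc3C)cc2)C(=O)C(C)C)c1`, gives 149 nM in an assay on isolated protein with Bile acid receptor (Homo sapiens) as the target; on this read-out lower numbers stand for an effect already at smaller amounts and higher numbers for an effect only at larger amounts of compound.
Compound 2, `COC(=O)/C=C/c1cccc(N(Cc2ccc(-c3cccc(OC)c3)cc2)C(=O)NC(C)C)c1`, gives 1370 nM in this assay.
Compound 3, `COC(=O)/C=C/c1cccc(N(Cc2ccc(-c3ccc(OC)cc3)cc2)C(=O)C2CCCCC2)c1`, gives 89 nM in this assay.

Among these three numbers compound 1 stands second highest. Its nearest neighbour is compound 3, whose number lies within the scatter of that of compound 1, so no order between the two can be claimed. Compound 2 lies beyond the scatter, with the higher number.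

Compound 4, `COC(=O)/C=C/c1cccc(N(Cc2ccc(-c3cc(Cl)ccc3OC)cc2)C(=O)C(C)C)c1`, has not yet been measured. It differs from compound 1 in one place: 5-chloro-2-methoxyphenyl in place of 2-(2,4,6-trimethylphenyl)ethenyl on an aromatic carbon. For the measured compounds named here, no measured pair shows this change. Compound 3, which also carries a methoxyphenyl group on that aromatic carbon, gives 89 nM, so the step of a 1.0-fold higher number from compound 1 to compound 4 (0.00 log units; within the scatter) is expected to be small, likely within the scatter, in either direction. Compound 4 is therefore estimated at 150 nM, with a range from 50 nM to 450 nM.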

Compound 4, half-maximal effective concentration: 226 nM
Estimate against measurement, compound 4: 1.5-fold (0.18 log units) below; the measured number falls inside the stated range.
By their numbers in this assay, from the lowest: compounds 3, 1 and 4 (each within the scatter of the next, the first and the last beyond it); then compound 2.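

Replacing 2-(2,4,6-trimethylphenyl)ethenyl with 5-chloro-2-methoxyphenyl gives a 1.5-fold higher number from compound 1 to compound 4 (0.18 log units; within the scatter) and so leaves the two numbers indistinguishable. At this aromatic carbon, then, a group with a double bond outside its ring and a directly attached ring bearing chlorine and methoxy can read alike. No available data explain this result. The compounds shown leave open what the chlorine and the methoxy group each contribute. They also leave open whether an amine or a carboxylic acid on this aromatic carbon would give a similar number.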